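Adding a ring hydroxy to compound 1: what to expect

A few compounds are considered here, and "the series" means these few. Any claim that something is new, unique, unknown or untested is made for them only; others in the source may bear on it.

- Compound 1 `CO[C@@H](C(=O)N[C@H]1CCCCNC1=O)[C@H](O)[C@@H](O)[C@H](O)/C=C/C(C)(C)C`: 1300 nM
- Compound 2 `CO[C@@H](C(=O)N[C@@H]1CCCCNC1=O)[C@H](O)[C@@H](O)[C@H](O)/C=C/C(C)(C)C`: 200 nM
- Compound 3 `CO[C@@H](C(=O)N[C@H]1CC[C@H](O)CNC1=O)[C@H](O)[C@@H](O)[C@H](O)/C=C/C(C)(C)C`: 145000 nM

In a functional assay on MCF7 cells (Homo sapiens) for cytotoxicity, read by colorimetric assay and neutral red uptake, with a stated time of 72 h (a lower number here means a stronger inhibitor, a higher number a weaker inhibitor), compound 1 stands in the middle of the three measured numbers, with compound 2 lower and compound 3 much higher. Compound 4 `CO[C@@H](C(=O)N[C@@H]1CC[C@H](O)CNC1=O)[C@H](O)[C@@H](O)[C@H](O)/C=C/C(C)(C)C` has not yet been measured. Its difference from compound 1 is 6-hydroxy-2-oxoazepan-3-yl in place of 2-oxoazepan-3-yl on an amide-type nitrogen. Compound 4 also has the configuration of compound 2 at the saturated ring stereocentre that separates compound 1 from compound 2.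

Among the compounds with values here, three measured steps bear on this change. Adding the hydroxy with nothing else altered gave a 110-fold higher number from compound 1 to compound 3 (2.05 log units; beyond the scatter), a large rise. Changing the configuration alone gave a 6.5-fold lower number from compound 1 to compound 2 (0.81 log units; beyond the scatter), a modest fall, and this step rests on (the fact that compounds 1 and 2 differ only in the configuration as drawn). The step of a 730-fold higher number from compound 2 to compound 3 (2.86 log units; beyond the scatter) also adds the hydroxy, but it reverses that configuration as well.

If the hydroxy raises the number for compound 2 about as much as it did for compound 1, the rise should outweigh the modest gain from the configuration. The expected result is a 17-fold higher number from compound 1 to compound 4 (1.23 log units; beyond the scatter), a clear move towards a weaker inhibitor in this assay. Compound 4 is expected at 22000 nM, with an estimated range of 5000 nM to 90000 nM.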

Compound 4, half-maximal inhibitory concentration: 80400 nM
For compound 4 the middle estimate is 3.7-fold (0.56 log units) below the measured one; low and high end bracket the measured number.
By their numbers in this assay, from the lowest: compound 2; then compound 1; then compounds 4 and 3 (each within the scatter of the next).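

In this assay, the hydroxy raises the number on both ring configurations, not only on compound 1, and the new step, a 400-fold higher number from compound 2 to compound 4 (2.60 log units; beyond the scatter), is the larger of the two: the same change on two cores in this assay, a 110-fold higher number (2.05 log units; beyond the scatter) from compound 1 to compound 3 and a 400-fold higher number (2.60 log units; beyond the scatter) from compound 2 to compound 4, 3.6-fold (0.56 log units) apart, beyond the scatter of two such steps. Within the data shown here, with the hydroxy in place, the ring stereocentre no longer separates the compounds as it did in a 6.5-fold lower number from compound 1 to compound 2 (0.81 log units; beyond the scatter), since a 1.8-fold lower number from compound 3 to compound 4 (0.26 log units; within the scatter) shows no difference that can be told from repeat measurements: the fact that compounds 3 and 4 differ only in the configuration as drawn. The configuration of compound 2 therefore brings no visible gain once the hydroxy is present, and the whole change gives a 62-fold higher number from compound 1 to compound 4 (1.79 log units; beyond the scatter).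

The compounds shown leave open whether any group on this ring carbon would cost as much as the hydroxy does, as a methoxy, a fluorine or an amine there would show, and whether the hydroxy with its own stereocentre drawn the other way would behave alike. A cell read-out of this kind also cannot say by itself why the number rises, so the cause of the hydroxy's large effect remains unknown.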